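The compounds below may be only part of what the source reports. "The series", "measured", "known", "first", "only" and "open" are said of these compounds alone.

Measured so far in an ADME assay on MRC5 cells (Homo sapiens), read by MTT assay, with a stated time of 72 h; a lower number here means a stronger inhibitor, a higher number a weaker inhibitor:

Compound 1, `COc1ncnc2c1c(-c1ccsc1)cn2[C@@H]1O[C@H](CO)[C@@H](O)[C@H]1O`, gives 75300 nM.
Compound 2, `COc1ncnc2c1c(-c1ccoc1)cn2[C@@H]1O[C@H](CO)[C@@H](O)[C@H]1O`, gives 29400 nM.
Compound 3, `CNc1ncnc2c1c(-c1ccsc1)cn2[C@@H]1O[C@H](CO)[C@@H](O)[C@H]1O`, reaches only a limit of the assay, > 100000 nM.

Compound 4, `CNc1ncnc2c1c(-c1ccoc1)cn2[C@@H]1O[C@H](CO)[C@@H](O)[C@H]1O`, is not yet measured in this assay.

The pair compound 1 to compound 2 carries the change (furan-3-yl in place of thiophen-3-yl on an aromatic carbon). Its effect is a 2.6-fold lower number from compound 1 to compound 2 (0.41 log units; beyond the scatter). The same change, word for word at the same place, is made in furan-3-yl in place of thiophen-3-yl on an aromatic carbon; among the compounds shown it occurs two times in all.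

The two cores differ by methylamino in place of methoxy on an aromatic carbon. Here the effect is an at least 1.3-fold higher number from compound 1 to compound 3 (0.12 log units; that floor lies within the scatter), and the value of compound 3 is only a limit, (the limit of > 100000 nM in this assay, at which 1 of the 3 values shown sits), so the true size of that step is not known.

For compound 3 to compound 4, the expected step is an at least 1.8-fold lower number from compound 3 to compound 4 (0.25 log units; that floor lies within the scatter), resting on the measured 2.6-fold lower number from compound 1 to compound 2 (0.41 log units; beyond the scatter) and on the limit that stands for compound 3 in this assay. Because compound 3 gives > 100000 nM, only a floor is set, and the expected value of compound 4 can be placed only loosely. The estimate for compound 4 in this assay is 55000 nM, with a lower end of 25000 nM and an upper end of 150000 nM, and a real chance that the assay again reports only a limit.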

Compound 4, half-maximal inhibitory concentration: > 100000 nM
Compound 4: only a limit was reported (the forecaster's own chance of this, stated with the estimate: 40%); at least 1.8-fold (0.25 log units) between middle value and limit.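

In this assay compound 4 gives > 100000 nM, which is a limit of the assay, and compound 3 also stands at a limit, so the step for furan-3-yl in place of thiophen-3-yl between these two compounds cannot be read, and that change cannot be compared across the two cores. Methylamino in place of methoxy, carried onto the core that bears furan-3-yl, gives an at least 3.4-fold higher number from compound 2 to compound 4 (0.53 log units; beyond the scatter), which makes a weaker result with methylamino the reading on this core, though only as a floor and not as a true size. Both pairs for this change point the same way, but this shows neither that the step is the same size on both cores nor that it is larger on one of them: the same change on two cores in this assay, an at least 1.3-fold higher number (0.12 log units; that floor lies within the scatter) from compound 1 to compound 3 and an at least 3.4-fold higher number (0.53 log units; beyond the scatter) from compound 2 to compound 4; the limit leaves it open whether they differ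

From the compounds shown here alone, the methylamino compounds give no measured number from which further steps could be sized: the limit of > 100000 nM in this assay, at which 2 of the 4 values shown sit. It remains open whether a plain amine or a dimethylamino group in place of methylamino, or an ethoxy group in place of methoxy, would give a value inside the measurable range and so allow the size of the step on each core to be read.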